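The compounds below may be only part of what the source reports. "The series", "measured", "known", "first", "only" and "open" are said of these compounds alone.

The measured compounds:

Compound 1, `COc1ccc(-c2cnc3nc(N)nc(NC(C)C)c3n2)cc1OC`: 600 nM
Compound 2, `COc1ccc(-c2cnc3nc(N)nc(N4CCN(Cc5ccc(C(C)(C)C)cc5)CC4)c3n2)cc1OC`: 4300 nM

Both were tested in a functional assay on cells (T-cell, Homo sapiens) for inhibition; a higher number here means a weaker inhibitor, a lower number a stronger inhibitor. Compound 1 gives 600 nM in this assay, the lower of the two numbers, and compound 2 gives 4300 nM, a gap that lies beyond the usual scatter. Compound 2 carries a large piperazine substituent where compound 1 has only an isopropylamino group, and the comparison of the two values shows that the smaller group goes with the stronger inhibition in this pair.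

The next compound, compound 3, `COc1ccc(-c2cnc3nc(N)nc(N4CCC(C)CC4)c3n2)cc1OC`, is an unmeasured analogue of compound 1. Its structure differs from compound 1 as follows: 4-methylpiperidin-1-yl in place of isopropylamino on an aromatic carbon. The change keeps the shared core and the amino group intact, removes the hydrogen-bond donor of the isopropylamino group and brings in a six-membered ring in its place.

On the basis of compound 1 at 600 nM and compound 2 at 4300 nM, the step of a 3.3-fold higher number from compound 1 to compound 3 (0.52 log units; beyond the scatter) is expected to lie beyond the scatter, toward weaker inhibition. Compound 3 is therefore estimated to give about 2000 nM in this assay, within a range of 600 nM to 7000 nM.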

Compound 3, half-maximal inhibitory concentration: 800 nM
For compound 3 the middle estimate is 2.5-fold (0.40 log units) above the measured one; low and high end bracket the measured number.
By their numbers in this assay, from the lowest: compounds 1 and 3 (each within the scatter of the next); then compound 2.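

In this assay, the step of a 1.3-fold higher number from compound 1 to compound 3 (0.12 log units; within the scatter) shows that this position, on an aromatic carbon next to the ring nitrogen, accepts 4-methylpiperidin-1-yl in place of isopropylamino with no change beyond the scatter. The exchange takes away the hydrogen-bond donor of the isopropylamino group and adds a six-membered non-aromatic ring, and the number stays level with that of compound 1, so in this pair neither the donor nor the open chain is needed to hold the inhibition. It also sets apart the two ring-bearing compounds: compound 3 gives 800 nM and compound 2 gives 4300 nM in this assay, so a ring at this position does not by itself go with the higher number seen for compound 2. No measurement on hand offers an explanation for these results.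

The compounds shown leave open whether the 4-methyl group of the piperidine contributes anything, which a plain piperidine or a morpholine at this position would address. They also leave open whether the higher number of compound 2 goes with the piperazine ring or with its 4-tert-butylbenzyl group, a question that an N-methylpiperazine or a 4-benzylpiperidine would bear on.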